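The compounds below may be only part of what the source reports. "The series", "measured", "known", "first", "only" and "open" are said of these compounds alone.

Measured so far:
Compound 1, `CN(C[C@H]1Cc2c(cccc2N2CCN(Cc3ccccn3)CC2)CN1)[C@H]1CCCc2cccnc21`, gives 4.2% in an ADME assay on microsomes from liver (Homo sapiens) for metabolic stability, read by LC-MS, with a stated time of 10 min; on this read-out higher numbers stand for a more stable compound and lower numbers for a less stable compound.
Compound 2, `CN(C[C@H]1Cc2c(cccc2N2CCN(C3COC3)CC2)CN1)[C@H]1CCCc2cccnc21`, gives 83.1% in this assay.
Compound 3, `CN(C[C@H]1Cc2c(cccc2N2CCN(c3cccc(C(F)(F)F)c3)CC2)CN1)[C@H]1CCCc2cccnc21`, gives 90.3% in this assay.

Compound 2 stands second highest of these three numbers. Its nearest neighbour is compound 3, and the step of a number 7.2 percentage points higher from compound 2 to compound 3 (within the scatter) lies within the scatter, so the two cannot be told apart. Its furthest neighbour is compound 1, and the step of a number 78.9 percentage points higher from compound 1 to compound 2 (beyond the scatter) is large.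

Compound 4, `CN(C[C@H]1Cc2c(cccc2N2CCNC(C)(C)C2)CN1)[C@H]1CCCc2cccnc21`, has not yet been measured in this assay. It differs from compound 2 in one place: 3,3-dimethylpiperazin-1-yl in place of 4-(oxetan-3-yl)piperazin-1-yl on an aromatic carbon.

The measured steps that bear on this change are those at the same position of the shared core. The steps of a number 78.9 percentage points higher from compound 1 to compound 2 (beyond the scatter) and a number 86.1 percentage points higher from compound 1 to compound 3 (beyond the scatter) were both large, while a number 7.2 percentage points higher from compound 2 to compound 3 (within the scatter) was within the scatter; so only compound 1 stands apart, and the two remaining groups on the amine nitrogen in a ring gave about the same stability. Going by the values given here, in compound 4 the whole 4-(oxetan-3-yl)piperazin-1-yl group leaves and a group with one hydrogen-bond donor enters; no measured step covers such an exchange. A small step downward, at most near the edge of the scatter, is expected: a number 13.1 percentage points lower from compound 2 to compound 4 (beyond the scatter). Compound 4 is therefore estimated at 70%, with a range from 40% to 95%.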

Compound 4, percent of the compound remaining: 100%
The estimate for compound 4 lay 30 percentage points below the measured number; the measured number lies above the stated range.
By their numbers in this assay, from the lowest: compound 1; then compounds 2, 3 and 4 (each within the scatter of the next, the first and the last beyond it).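

The earlier compounds shown here differed only in the group on an amine nitrogen in a ring, whereas this change replaces the whole group on the aromatic carbon, and in this assay it gives a number 16.9 percentage points higher from compound 2 to compound 4 (beyond the scatter). So stability at this position does not depend on keeping the 4-(oxetan-3-yl)piperazin-1-yl group: the smaller 3,3-dimethylpiperazin-1-yl group, with 1 hydrogen-bond donor, does not lower the number, and compound 4 reaches 100% on this read-out. No measurement here accounts for the rise in the number. 

The step also combines several differences at once, so the compounds shown leave open whether the two methyl groups, the loss of the oxetane ring or the hydrogen-bond donor matters most. A plain piperazin-1-yl group would separate the methyl groups from the rest, while a morpholin-4-yl group would show whether a second ring nitrogen is needed at this aromatic carbon at all.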